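Swapping the aryl group on a coumarin chalcone

The source may report more compounds than this note shows. Statements on the series, on what has been measured and on what is new or still open speak of the compounds shown alone.

Compound 1 `COc1ccc(/C=C/C(=O)c2cc3ccc(OCc4cccc(OC)c4)cc3oc2=O)cc1` was tested in a functional assay on MOLT-4 cells (Homo sapiens) for cytotoxicity, read by MTT assay, with a stated time of 72 h (a lower number here means a stronger inhibitor, a higher number a weaker inhibitor), where compound 1 gives only a limit of the assay, > 100000 nM. Compound 2 `COc1cccc(COc2ccc3cc(C(=O)/C=C/c4ccc(Cl)cc4Cl)c(=O)oc3c2)c1` shares the core of compound 1 but carries a different aryl group on its double-bonded chain; in this assay compound 2 stands at "not determined" (no result reported), so no number is known for it. Among the measured compounds shown here, the only value shown in this assay is therefore that of compound 1 (the limit of > 100000 nM in this assay, at which 1 of the 2 values shown sits). Compound 3 `COc1cccc(COc2ccc3cc(C(=O)/C=C/c4ccc(C)cc4)c(=O)oc3c2)c1` differs from compound 2 in one place: 4-methylphenyl in place of 2,4-dichlorophenyl on a double-bonded chain carbon bound to a double-bonded chain carbon. Because no step between two measured compounds exists here, the size of the step from compound 2 to compound 3 cannot be read from the numbers shown, and no change beyond the usual scatter is assumed in either direction. Compound 3 is estimated to give 100000 nM in this assay, with an expected range from 30000 nM to 300000 nM, most likely again reported only as a limit.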

Compound 3, half-maximal inhibitory concentration: > 50000 nM
Compound 3: only a limit was reported (the forecaster's own chance of this, stated with the estimate: 70%); the middle value lies beyond the limit too.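

Compound 1 and compound 3 are each reported only as a limit in this assay, and the step between them, methyl in place of methoxy on an aromatic carbon, cannot be read. The compounds shown leave open whether any aryl group on the shared core gives a measurable number.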